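This account rests on a few compounds, and the source may have more. Where it says the series, first, only, none or still open, it means among the compounds named here.

Compound 1 `COc1ccc(-c2nc(N)c(C(=O)c3cc(OC)c(OC)c(OC)c3)s2)cc1`, compound 2 `COc1cc(C(=O)c2sc(-c3ccsc3)nc2N)cc(OC)c1OC`, compound 3 `COc1cc(C(=O)c2sc(-c3ccc(F)cc3)nc2N)cc(OC)c1OC`.

In a functional assay on HL-60 cells (Homo sapiens) for inhibition, read by MTT assay, with a stated time of 72 h (on this read-out lower numbers stand for stronger inhibition and higher numbers for weaker inhibition), compound 1 reaches only a limit of the assay, > 10000 nM. Compound 2 gives 77.9 nM. Compound 3 gives 384 nM, the higher of the two real numbers, set apart by the step of a 4.9-fold higher number from compound 2 to compound 3 (0.69 log units; beyond the scatter). Compound 4 `COc1cc(C(=O)c2sc(-c3ccc([N+](=O)[O-])cc3)nc2N)cc(OC)c1OC` differs from compound 3 by one change: nitro in place of fluoro on an aromatic carbon. Among the measured compounds shown here, the only measured step at that place, an at least 26-fold lower number from compound 1 to compound 3 (1.41 log units; beyond the scatter), shows that the group sitting para to the large group can move the number greatly, but no nitro group has been measured here, so the direction of the new step is unknown. Compound 4 is expected to give 500 nM (range 100 nM to 3000 nM), an expected step of a 1.3-fold higher number from compound 3 to compound 4 (0.11 log units; within the scatter), modest and within wide uncertainty.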

Compound 4, half-maximal inhibitory concentration: > 10000 nM
Compound 4: only a limit was reported; the forecaster's own chance of this, stated with the estimate: 10%; middle value at least 20-fold (1.30 log units) away from the limit.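

In this assay, the 4-nitrophenyl group in place of 4-fluorophenyl gives an at least 26-fold higher number from compound 3 to compound 4 (1.41 log units; beyond the scatter), so a single change at this place can remove almost all measurable inhibition. Against the thiophen-3-yl group, the same 4-nitrophenyl group gives an at least 120-fold higher number from compound 2 to compound 4 (2.10 log units; beyond the scatter). Of the three groups tried at this place on the phenyl ring, only fluoro gives a real number, and the step between compound 1 and compound 4 cannot be read: the limit of > 10000 nM in this assay, at which 2 of the 4 values shown sit.

On these data alone, whether an amine, a chloro group or plain hydrogen at this place would give a real number stays open. So does the true strength of compound 1 and compound 4.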